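The source may hold more compounds than are shown below. What is called first, only, known or untested is meant among the compounds shown, and "the series" means these compounds.

Measured in a functional assay on MCF-10A cells (Homo sapiens) for cytotoxicity, read by sulforhodamine B assay, with a stated time of 2 days; on this read-out lower numbers stand for stronger inhibition and higher numbers for weaker inhibition:
Compound 1 `Cc1cc(N(C)C)ccc1-c1nc2c(s1)[C@H](O)CCC2`: > 100000 nM
Compound 2 `OC1CCCc2nc(-c3ccc(N4CCCC4)cc3)sc21`: > 100000 nM

Neither entry is an exact number. Compound 1 stands at > 100000 nM, which is a limit of the assay. Compound 2 stands at > 100000 nM, which is also a limit. Together they amount to the limit of > 100000 nM in this assay, at which 2 of the 2 values shown sit, so compound 1 has no exact position and no measured step to compare with.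

Compound 3 `Cc1cc(N(C)C)ccc1-c1nc2c(s1)[C@@H](O)CCC2` is not yet measured. It keeps everything in compound 1 apart from one detail: the two compounds have the same atoms and bonds and differ only in configuration as drawn: 1 of 1 stereo elements differ; a stereocentre at a saturated ring carbon is drawn R in compound 1 and S in compound 3.

Going by the values given here, no measured pair shows what such a switch does in this assay, so no step beyond the usual scatter is expected, in either direction. The expected change is a number no higher from compound 1 to compound 3 (the limit leaves the size open). This expectation starts from compound 1 and its limit of > 100000 nM. The estimate for compound 3 is 100000 nM, with an expected range from 30000 nM to 200000 nM.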

Compound 3, half-maximal inhibitory concentration: > 100000 nM
Compound 3 was reported as a limit; the forecaster's own chance of this, stated with the estimate: 80%; the middle value lies on the limit itself.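

Compound 1 and compound 3 differ only in the configuration at one stereocentre, yet no step can be read between them in this assay, since both values are limits: the limit of > 100000 nM in this assay, at which 3 of the 3 values shown sit.

The compounds shown leave open whether that configuration makes any difference, and what exact number any of them would give in this assay.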